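This account rests on a few compounds, and the source may have more. Where it says the series, first, only, none or still open, it means among the compounds named here.

Measured compounds: compound 1 is `Cc1ccc(C2=NN(c3ccc(S(C)(=O)=O)cc3)C(=O)CC2)cc1`, compound 2 is `CS(=O)(=O)c1ccc(N2N=C(c3ccccc3)CCC2=O)cc1` and compound 3 is `Cc1cc(O)ccc1C1=NN(c2ccc(S(C)(=O)=O)cc2)C(=O)CC1`. In a functional assay on the whole organism (strain Wistar) for inhibition, with Rattus norvegicus as the target, read by paw edema, with stated times of 30 min and 5 h, at a dose of 0.05 mmol/kg by the oral route (a higher number here means more inhibition at the dose given (going by the name of the read-out), a lower number less inhibition), compound 1 gives 60.5%, compound 2 gives 47.3%, and compound 3 gives 52.6%.

Compound 2 holds the lowest of the three numbers; its nearest neighbour is compound 3, within the scatter, while its gap to compound 1 lies beyond it. Compound 4 is `CS(=O)(=O)c1ccc(N2N=C(c3ccc(-c4ccccc4)cc3)CCC2=O)cc1`. It differs from compound 2 by phenyl in place of hydrogen on an aromatic carbon. Among the measured compounds shown here, the only measured step touching this place is a number 13.2 percentage points lower from compound 1 to compound 2 (beyond the scatter), a modest loss when a methyl is taken away from an aromatic carbon. Read backwards, adding a small group there gave a modest gain; the entering phenyl is much larger, and no measured compound shows a group of that size, so a small rise at most is expected. Compound 4 is therefore estimated at 54%, between 36% and 70%, an expected step of a number 6.7 percentage points higher from compound 2 to compound 4 (within the scatter).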

Compound 4, a percentage reported as inhibition, in the whole organism at one dose (the size of the read-out at that dose, not a potency): 21%
For compound 4 the middle estimate is 33 percentage points above the measured one; the whole stated range lies above it.
By their numbers in this assay, from the lowest: compound 4; then compounds 2, 3 and 1 (each within the scatter of the next, the first and the last beyond it).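

At this aromatic carbon, adding a group does not always raise the number: methyl gave a gain, but phenyl in place of hydrogen brings a number 26.3 percentage points lower from compound 2 to compound 4 (beyond the scatter) and phenyl in place of methyl brings a number 39.5 percentage points lower from compound 1 to compound 4 (beyond the scatter) in the same test. The outcome therefore depends on which group enters, and a group that helps here cannot be taken as a guide to a much larger one. No measurement shown explains this drop. On these data alone, what an ethyl, a methoxy or an amine would give at this carbon stays open, so the point where gain turns to loss cannot be placed.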